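Bromo in place of chloro: compound 2 to compound 3

This account rests on a few compounds, and the source may have more. Where it says the series, first, only, none or still open, it means among the compounds named here.

- compound 1 `O=C(Nc1ccc(C(F)(F)F)cc1)c1cc(Br)ccc1O`: < 100000 nM (a limit)
- compound 2 `O=C(Oc1ccc(Cl)cc1C(=O)Nc1ccc(C(F)(F)F)cc1)c1cnc(Cl)cn1`: < 100000 nM (a limit)

In a physicochemical assay for solubility, read by spectrophotometry (on this read-out lower numbers stand for lower solubility and higher numbers for higher solubility), compound 2 stands only at a limit, < 100000 nM. Compound 1 is likewise recorded only as a limit, < 100000 nM. The measured set therefore comes down to the limit of < 100000 nM in this assay, at which 2 of the 2 values shown sit. Neither compound has a number, so no order between them can be stated.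

Compound 3 `O=C(Oc1ccc(Br)cc1C(=O)Nc1ccc(C(F)(F)F)cc1)c1cnc(Cl)cn1` differs from compound 2 in one place: bromo in place of chloro on an aromatic carbon. This is bromo in place of chloro on an aromatic carbon, meta to a large group and para to a ((5-chloropyrazin-2-yl)carbonyl)oxy group.

Among the compounds with values here, no measured step covers this change, so no move beyond the scatter is expected in this assay, in either direction. The expectation rests on compound 2, a limit at < 100000 nM. The expected step is a step that the limit leaves unreadable from compound 2 to compound 3. A report as a limit is the likeliest outcome. For compound 3 the estimated value is 60000 nM, with an expected range of 20000 nM to 100000 nM.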

Compound 3, solubility: < 100000 nM
Compound 3: no number, only a limit (the forecaster's own chance of this, stated with the estimate: 90%); the middle value does not contradict the limit.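

No new step can be read for compound 3 against compound 2 or compound 1 in this assay, since all three are recorded only as limits: the limit of < 100000 nM in this assay, at which 3 of the 3 values shown sit.

The compounds shown leave open whether bromo in place of chloro, or (5-chloropyrazin-2-yl)carbonyl in place of hydrogen, moves this read-out at all.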